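Adding a Chloro Group to Compound 3

A few compounds are considered here, and "the series" means these few. Any claim that something is new, unique, unknown or untested is made for them only; others in the source may bear on it.

Within the data shown here, compound 3 (`O=S(=O)(O)Nc1ccc(-c2nc3ccccc3s2)cc1`) holds the only true number in this small set: in a physicochemical assay for lipophilicity, measured as octanol-water partition, at pH 7.4 (on this read-out lower numbers stand for lower lipophilicity and higher numbers for higher lipophilicity), compound 3 gives 3.4. Compound 1 (`Nc1ccc(-c2nc3ccccc3s2)cc1I`) gives > 3.3, which is a limit and not a number. Compound 2 (`Nc1ccc(-c2nc3ccccc3s2)cc1Br`) gives > 3.3, which is also a limit. Neither of these two carries the sulfoamino group of compound 3.

The next compound to be measured is compound 4 (`O=S(=O)(O)Nc1ccc(-c2nc3ccccc3s2)cc1Cl`), and one change separates it from compound 3: chloro in place of hydrogen on an aromatic carbon.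

The measured data offer little guidance on the size of this change. Among the measured compounds shown here, the only measured step is a step that the two limits leave unreadable from compound 1 to compound 2, and it swaps one halogen for another rather than adding one in place of hydrogen. The one further clue is the limit of > 3.3 in this assay, at which 2 of the 3 values shown sit, and the two compounds at that limit carry iodo and bromo.

Starting from compound 3 at 3.4, a modest rise in this assay is expected, though with wide uncertainty. The expected change is a number 0.30 log units higher from compound 3 to compound 4 (within the scatter). Compound 4 is estimated at 3.7, with an expected range from 3.2 to 4.2.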

Compound 4, distribution coefficient: 0.02
Estimate against measurement, compound 4: 3.68 log units above; the measured number lies below the stated range.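

In this assay, putting chloro on an aromatic carbon, ortho to a sulfoamino group, proves to be far from a minor edit: the result is a number 3.38 log units lower from compound 3 to compound 4 (beyond the scatter). Among these compounds, this is the first step in the set whose size can be read, and the first to put a halogen in place of hydrogen rather than swap one halogen for another. The step between the iodo and bromo compounds cannot be read, and those two compounds lack the sulfoamino group, so they give no measured size to set beside this one: the limit of > 3.3 in this assay, at which 2 of the 4 values shown sit.

The single step shown cannot tell whether this large drop belongs to chloro itself or would appear with other groups on the same aromatic carbon, such as fluoro, methyl or methoxy. It also leaves open whether chloro would shift the reading as far if a carboxylic acid or an amide stood in place of the sulfoamino group.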